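A few compounds are considered here, and "the series" means these few. Any claim that something is new, unique, unknown or untested is made for them only; others in the source may bear on it.

Working notes on the series of semicarbazones built on the shared core of compound 1 `COc1cc(/C=N/NC(=O)Nc2cccc3ccccc23)ccc1O`, compound 2 `O=C(N/N=C/c1ccc(O)cc1)Nc1cccc2ccccc12` and compound 3 `C/C(=N\NC(=O)Nc1cccc2ccccc12)c1ccccc1`. In a functional assay on the whole organism (strain Swiss albino) with Mus musculus as the target, in the maximal electroshock model, with a stated time of 0.5 h (a lower number here means that less compound is needed, a higher number that more compound is needed for the effect), compound 1 gives 300 mg/kg, compound 2 gives 100 mg/kg and compound 3 gives 300 mg/kg. Compound 2 stands at the lowest of the three numbers in this assay, with compound 1 and compound 3 each sitting above it, and both of those gaps lie beyond the scatter.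

Among the compounds with values here, the one single-place step measured so far is a 3.0-fold lower number from compound 1 to compound 2 (0.48 log units; beyond the scatter). Compound 4 `O=C(N/N=C/c1ccccc1)Nc1cccc2ccccc12` is not yet measured in this assay. It differs from compound 2 by hydrogen in place of hydroxy on an aromatic carbon. Within the data shown here, no measured step removes a hydroxy group; the step from compound 1 to compound 2 concerns a methoxy group on the same ring and points only loosely at what a change at the para position may do. Compound 3, which also carries a plain phenyl ring but with a methyl on the imine carbon, sits at 300 mg/kg, a higher number than compound 2.

Taken together, the expectation for compound 4 is a small rise in the minimum effective dose, or no change beyond the scatter, so that the estimated step is a 2.0-fold higher number from compound 2 to compound 4 (0.30 log units; within the scatter). Compound 4 is therefore estimated at 200 mg/kg, with a range from 100 mg/kg to 600 mg/kg.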

Compound 4, minimum effective dose: 300 mg/kg
For compound 4 the middle estimate is 1.5-fold (0.18 log units) below the measured one; the range from low to high includes it.
By their numbers in this assay, from the lowest: compound 2; then compounds 1, 3 and 4 (each within the scatter of the next).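

In this assay, within the data shown here, the change from 4-hydroxyphenyl to phenyl reads as a 3.0-fold higher number from compound 2 to compound 4 (0.48 log units; beyond the scatter) and is the first measured step that removes the hydroxy itself, showing that hydrogen at this place, para to a large group, does not keep the number of compound 2. Read with a 3.0-fold lower number from compound 1 to compound 2 (0.48 log units; beyond the scatter) on the same ring, compound 2 is now linked by a single change on each side, and both steps lie beyond the scatter, leaving the 4-hydroxyphenyl ring without a methoxy group at the lowest number among the compounds shown. No measurement available here bears on what lies behind this step.

Open, from the compounds shown here alone, is whether another group at this place, such as an amine or a carboxylic acid, would stay with compound 2 or sit with compound 4. Going by these compounds, compound 3 gives 300 mg/kg and compound 4 gives 300 mg/kg in this assay, the same printed value, and what a methyl on the imine carbon would do alongside the 4-hydroxyphenyl ring also stays open.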